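The source may hold more compounds than are shown below. What is called first, only, known or untested is meant among the compounds shown, and "the series" means these compounds.

In a functional assay on Huh-7 cells (Homo sapiens) for inhibition, read by CCK-8 assay, with a stated time of 72 h (a higher number here means a weaker inhibitor, a lower number a stronger inhibitor), compound 1 `O=C(/C=C/c1cccnc1)NCCCCCCc1cccc(S(=O)(=O)Nc2ccccc2)c1` gives 2.82 nM, and compound 2 `O=C(/C=C/c1cccnc1)NCCCCCCc1cccc(S(=O)(=O)Nc2ccc(Cl)cc2)c1` gives 24.1 nM. Compound 2 therefore has the higher of the two numbers and is the weaker inhibitor of this pair. Compound 3 `O=C(/C=C/c1cccnc1)NCCCCCCc1cccc(S(=O)(=O)Nc2ccc(Oc3ccccc3)cc2)c1` keeps the shared core and differs from compound 2 in one group, with phenoxy in place of chloro on an aromatic carbon. Within the data shown here, only one measured step bears on this change: an 8.5-fold higher number from compound 1 to compound 2 (0.93 log units; beyond the scatter), a modest loss of potency seen when chloro replaced hydrogen on an aromatic carbon. That single step involves no group as large as phenoxy, so it gives only a weak guide to direction. No step beyond the scatter is therefore expected in this assay, although the uncertainty is wide on both sides. The expected step is a 1.5-fold higher number from compound 2 to compound 3 (0.16 log units; within the scatter). The estimated value for compound 3 is 35 nM, with an expected range of 6 nM to 200 nM.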

Compound 3, half-maximal inhibitory concentration: 32.7 nM
For compound 3 the middle estimate is 1.1-fold (0.03 log units) above the measured one; the measured number falls inside the stated range.
By their numbers in this assay, from the lowest: compound 1; then compounds 2 and 3 (each within the scatter of the next).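

In this assay, replacing the single chlorine atom with phenoxy, which brings seven heavy atoms and a six-membered aromatic ring, changes little: a 1.4-fold higher number from compound 2 to compound 3 (0.13 log units; within the scatter). Against the hydrogen of compound 1, however, the phenoxy group gives a large loss of potency, a 12-fold higher number from compound 1 to compound 3 (1.06 log units; beyond the scatter), so at this position chloro and phenoxy are both weaker than hydrogen, and the much bigger group is not separated from the small one. No measurement here offers a reason for this result.

The compounds shown leave open whether a group such as methyl, an amine or a carboxylic acid at this same position would also fall short of hydrogen. They also leave open whether a longer chain in place of phenoxy would stay level with chloro.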